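This account rests on a few compounds, and the source may have more. Where it says the series, first, only, none or still open, it means among the compounds named here.

Three compounds have been measured in a physicochemical assay for acid dissociation:
compound 1 `COc1ccc(Oc2ccc3c(NCCCNCc4cc(F)ccc4OC)ccnc3c2)cc1`, which gives 9.28;
compound 2 `COc1cccc(CNCCCNc2ccnc3cc(-c4ccc(C(C)(C)C)cc4)ccc23)c1O`, which gives 9.47;
compound 3 `CC(C)(C)c1ccc(-c2ccc3c(NCCCNCc4ccco4)ccnc3c2)cc1`, which gives 9.47.

Compound 2 stands level with compound 3, and together they hold the highest of the three numbers; compound 1 differs from compound 2 only within the scatter. Compound 4 `COc1cccc(CNCCCNc2ccnc3cc(Oc4ccc(C(C)(C)C)cc4)ccc23)c1O` differs from compound 2 in one place: 4-(tert-butyl)phenoxy in place of 4-(tert-butyl)phenyl on an aromatic carbon. Among the compounds with values here, no measured step changes this part of the shared core. Within the data shown here, the one step recorded, no change at the digits printed from compound 2 to compound 3 (within the scatter), alters the group on the chain instead. Compound 1, which also carries an aryl ether on its core but differs from compound 2 in more than one place, gives a value within the scatter of compound 2. The step from compound 2 to compound 4 is therefore expected to stay within the scatter, a number 0.05 log units lower from compound 2 to compound 4 (within the scatter). Compound 4 is estimated at 9.42, in the range 9.12 to 9.72.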

Compound 4, acid dissociation constant: 9.28
For compound 4 the middle estimate is 0.14 log units above the measured one; the measured number falls inside the stated range.
By their numbers in this assay, from the lowest: compounds 1, 4, 2 and 3 (each within the scatter of the next).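

Within the data shown here, replacing 4-(tert-butyl)phenyl with 4-(tert-butyl)phenoxy on this aromatic carbon of the shared core gives the only one-place comparison at this position in this assay: a number 0.19 log units lower from compound 2 to compound 4 (within the scatter). This swap, which adds one oxygen and one hydrogen-bond acceptor, therefore stays within the usual spread of repeated measurements. Nothing available explains this result. Still open, from the compounds shown here alone, is whether a carboxylic acid or a nitrile at this position would stay within that spread. Also open, going by these compounds, is whether the same swap would read alike with furan-2-yl on the chain.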